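The source may hold more compounds than are shown below. What is called first, only, known or untested is meant among the compounds shown, and "the series" means these compounds.

Working notes on the coumarin-hydrazone series, three compounds measured so far.

Compound 1 `O=C(N/N=C/c1ccncc1)c1cc2ccccc2oc1=O` gives 9750 nM in a functional assay on PANC-1 cells (Homo sapiens) for antiproliferative activity, read by fluorescence and resazurin assay, with a stated time of 48 h; a lower number here means a stronger inhibitor, a higher number a weaker inhibitor. Compound 2 `O=C(N/N=C/c1cccnc1)c1cc2cc(Br)ccc2oc1=O` gives 8350 nM in this assay, a number close to that of compound 1. Compound 3 `O=C(N/N=C/c1cccnc1)c1cc2ccc(O)cc2oc1=O` gives 2530 nM in this assay, the lowest of the three numbers; its separation from compound 2, the nearest, and from compound 1, the furthest, lies beyond the usual scatter in each case. Among the measured compounds shown here, compound 3 is the only one of the three carrying a hydroxy on the shared core, and the only one with a number clearly apart from the others.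

Compound 4 `O=C(N/N=C/c1cccnc1)c1cc2ccccc2oc1=O` is not yet measured. It differs from compound 3 in one place: hydrogen in place of hydroxy on an aromatic carbon. With the hydroxy gone, compound 4 resembles compounds 1 and 2 more than compound 3 in what sits on the core. The step is therefore expected to go toward a higher number in this assay, and the expected step of a 2.6-fold higher number from compound 3 to compound 4 (0.41 log units; beyond the scatter) is taken to lie beyond the scatter, though not necessarily all the way to the numbers of compounds 1 and 2. Compound 4 is estimated at 6500 nM, with a range of 2500 nM to 15000 nM.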

Compound 4, half-maximal inhibitory concentration: 15300 nM
Beside the measured number, compound 4's estimate is 2.4-fold (0.37 log units) below it, and the stated range ends below it.
By their numbers in this assay, from the lowest: compound 3; then compounds 2, 1 and 4 (each within the scatter of the next).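

In this assay, among the compounds shown here, the step of a 6.0-fold higher number from compound 3 to compound 4 (0.78 log units; beyond the scatter) ties the lower number of compound 3 to one change, hydrogen in place of hydroxy on an aromatic carbon, which the earlier compounds, differing from each other in more than one place, could not show. The other two changes do not separate their compounds, since the steps of a 1.8-fold higher number from compound 2 to compound 4 (0.26 log units; within the scatter) and a 1.6-fold higher number from compound 1 to compound 4 (0.20 log units; within the scatter) both lie within the usual scatter, so among these four compounds only the hydroxy gives a number clearly apart. Nothing at hand gives a reason for the size of the hydroxy step.

Going by these compounds, whether a methoxy or an amine on the same aromatic carbon would keep the lower number remains open. Also open, on these data alone, is whether the hydroxy gives a similar step when the hydrazone carries pyridin-4-yl.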